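Lengthening the Carbamate Chain on an Aryl Selenocyanate Core

The source may hold more compounds than are shown below. What is called first, only, known or untested is meant among the compounds shown, and "the series" means these compounds.

Compound 1, `CCCOC(=O)Nc1ccc([Se]C#N)cc1`: 28900 nM
Compound 2, `O=C(Nc1ccc([Se][Se]c2ccc(NC(=O)OCc3ccc([N+](=O)[O-])cc3)cc2)cc1)OCc1ccc([N+](=O)[O-])cc1`: 31800 nM
Compound 3, `CCOC(=O)Nc1ccc([Se]C#N)cc1`: 24900 nM

In a functional assay on HTB-54 cells (Homo sapiens) for cytotoxicity, read by MTT assay, with a stated time of 72 h (a lower number here means a stronger inhibitor of growth, a higher number a weaker inhibitor of growth), compound 3 gives 24900 nM, a number that cannot be told apart from those of compound 1 or compound 2, since its gap to each lies within the scatter. Going by the values given here, the only single-point step that has been measured is a 1.2-fold lower number from compound 1 to compound 3 (0.06 log units; within the scatter), and it shows no change beyond the scatter. Compound 4, `CCCCOC(=O)Nc1ccc([Se]C#N)cc1`, differs from compound 3 by ethyl in place of hydrogen on a saturated chain carbon, two bonds along the chain from an oxygen next to a carbonyl group. Among the compounds with values here, this is the same kind of change as the one between compound 1 and compound 3, extended by a further carbon, so no step beyond the scatter is expected. Compound 4 is therefore estimated to give 27000 nM in this assay, within a range of 13000 nM to 56000 nM, which would mean an expected step of a 1.1-fold higher number from compound 3 to compound 4 (0.04 log units; within the scatter).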

Compound 4, concentration for 50% growth inhibition: 17200 nM
Compound 4: middle estimate off by 1.6-fold (0.20 log units), on the high side, and the stated range covers the measured number.
By their numbers in this assay, from the lowest: compounds 4, 3, 1 and 2 (each within the scatter of the next).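

Across this assay, the change from ethoxy to butoxy gives a 1.4-fold lower number from compound 3 to compound 4 (0.16 log units; within the scatter), and the step from the chain of compound 1 gives a 1.7-fold lower number from compound 1 to compound 4 (0.23 log units; within the scatter), so all three carbamate chains on the shared core lie within the scatter of one another. This position therefore shows no step beyond the scatter over a wider span of chain than the earlier pair covered. Nothing available bears on the reason for these numbers. Still open, going by these compounds, is whether a longer chain, such as hexyl, or a chain ending in an amine or a carboxylic acid, would produce a step beyond the scatter.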